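The source may report more compounds than this note shows. Statements on the series, on what has been measured and on what is new or still open speak of the compounds shown alone.

In a functional assay on HCT-116 cells (Homo sapiens) for cytotoxicity (a higher number here means a weaker inhibitor, a lower number a stronger inhibitor), compound 1 (`COc1cc(N2CCN(C(=O)N3CCN(C)CC3)CC2)ccc1Nc1nc(NC2CCCCC2)c2nc[nH]c2n1`) gives 17 nM and compound 2 (`COc1cc(N2CCN(C(=O)N3CCC(O)C3)CC2)ccc1Nc1nc(NC2CCCCC2)c2nc[nH]c2n1`) gives 27 nM. Compound 3 (`COc1cc(N2CCC(CC(=O)N3CCN(C)CC3)CC2)ccc1Nc1nc(NC2CCCCC2)c2nc[nH]c2n1`) gives 51 nM. This number lies within the scatter of the value for compound 2, and beyond the scatter above the value for compound 1.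

Compound 4 (`COc1cc(N2CCC(C(=O)N3CC(O)C3)CC2)ccc1Nc1nc(NC2CCCCC2)c2nc[nH]c2n1`) differs from compound 3 by (3-hydroxyazetidin-1-yl)carbonyl in place of ((4-methylpiperazin-1-yl)carbonyl)methyl on a saturated ring carbon: (3-hydroxyazetidin-1-yl)carbonyl stands in place of ((4-methylpiperazin-1-yl)carbonyl)methyl on a saturated ring carbon. Within the data shown here, only one measured step bears on this change, and only in part. In a 1.6-fold higher number from compound 1 to compound 2 (0.20 log units; within the scatter), 3-hydroxypyrrolidin-1-yl replaces 4-methylpiperazin-1-yl on a carbonyl carbon, and that step stays within the scatter. Among the measured compounds shown here, no measured compound carries the (3-hydroxyazetidin-1-yl)carbonyl group, so the expectation remains uncertain. In this assay, no step beyond the scatter is expected in either direction, and the expected step is a 1.1-fold lower number from compound 3 to compound 4 (0.05 log units; within the scatter). For compound 4 the estimated value is 45 nM, with an expected range from 15 nM to 130 nM.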

Compound 4, half-maximal inhibitory concentration: 50 nM
Estimate against measurement, compound 4: 1.1-fold (0.05 log units) below, and the stated range covers the measured number.
By their numbers in this assay, from the lowest: compounds 1, 2, 4 and 3 (each within the scatter of the next, the first and the last beyond it).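

In this assay, the exchange of ((4-methylpiperazin-1-yl)carbonyl)methyl for (3-hydroxyazetidin-1-yl)carbonyl gives a 1.0-fold lower number from compound 3 to compound 4 (0.01 log units; within the scatter). This shows that, on this saturated ring carbon three ring bonds from the ring nitrogen, the two groups cannot be told apart, even though they differ in ring size, in hydrogen-bond donors and in the methyl link that only the leaving group carries. Nothing available explains why the number holds across this change.

On these data alone, since the ring, the hydroxyl and the link all change in one step, the share of each stays open. As far as these compounds go, it also remains open whether (4-methylpiperazin-1-yl)carbonyl set directly on the same ring carbon, or a carboxylic acid or primary amine there, would fall within the scatter of these two compounds in this assay.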